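A few compounds are considered here, and "the series" means these few. Any claim that something is new, unique, unknown or untested is made for them only; others in the source may bear on it.

Measured compounds:
- compound 1, `COc1cc(-c2nn(-c3cccc(NC(=O)c4cccc(C(F)(F)F)c4)c3)cc2-c2ccncc2)ccc1Cl`: 2980 nM
- compound 2, `O=C(Nc1cccc(-n2cc(-c3ccncc3)c(-c3ccc(Cl)c(O)c3)n2)c1)Nc1cc(C(F)(F)F)cc(C(F)(F)F)c1`: 1200 nM

In a functional assay on OVCAR-3 cells (Homo sapiens) for inhibition, read by sulforhodamine B assay, with a stated time of 48 h (on this read-out higher numbers stand for weaker inhibition of growth and lower numbers for stronger inhibition of growth), compound 1 gives 2980 nM, and of the two numbers recorded this is the higher one. The nearest neighbour is compound 2, which in this assay gives 1200 nM, a gap beyond the usual scatter, so compound 1 is the weaker growth inhibitor of the two. The two compounds differ in more than one place, so no single structural change can be read out of that gap.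

Compound 3, `COc1cc(-c2nn(-c3cccc(NC(=O)c4ccccc4)c3)cc2-c2ccncc2)ccc1Cl`, has not yet been measured. It keeps the core of compound 1 and differs from it in one place: hydrogen in place of trifluoromethyl on an aromatic carbon. The trifluoromethyl, four heavy atoms, is lost and only a hydrogen takes its place, leaving the amide and the rest of the molecule untouched. Going by the values given here, no measured pair shows the effect of exactly this change, so the expectation rests on the structural change alone. Losing a group of this size is expected to cost some growth inhibition, giving a step of a 2.0-fold higher number from compound 1 to compound 3 (0.30 log units; within the scatter) that is likely beyond the scatter. Compound 3 is therefore expected to give 6000 nM in this assay, with a range from 2500 nM to 20000 nM.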

Compound 3, concentration for total growth inhibition: 10900 nM
Compound 3: middle estimate off by 1.8-fold (0.26 log units), on the low side; measured number inside the range.
By their numbers in this assay, from the lowest: compound 2; then compound 1; then compound 3.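

In this assay, going by these compounds alone, the change from 3-(trifluoromethyl)phenyl to phenyl gives the first single-change comparison in this set, with a 3.7-fold higher number from compound 1 to compound 3 (0.56 log units; beyond the scatter) when the trifluoromethyl gives way to hydrogen. The earlier pair of compound 1 and compound 2 differed in more than one place and could not isolate any one group, whereas this pair shows that this position on the ring matters: with the rest of the molecule unchanged, the compound carrying trifluoromethyl inhibits growth more strongly than the one carrying hydrogen. Nothing available here bears on the reason for this step.

As far as these compounds go, what remains open is whether that advantage is specific to trifluoromethyl or would also appear with another group at the same place, such as a methyl, a chlorine or a nitrile. Also unsettled is whether losing a trifluoromethyl would cost as much in compound 2, which has a different linker and a hydroxyl in place of the methoxy, so this one pair cannot be extended to it.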